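The compounds below may be only part of what the source reports. "The series", "measured", "known", "first", "only" and "open" are said of these compounds alone.

Three compounds built on a shared core were tested in a functional assay on cells for agonist activity at C-X-C chemokine receptor type 4 (Homo sapiens), read by fluorescence and calcium flux, with a stated time of 90 s; a lower number here means that less compound is needed, a higher number that more compound is needed for the effect. Compound 1 `c1ccc2c(c1)CN[C@@H](CN(CCCCNC1CCOCC1)[C@H]1CCCc3cccnc31)C2` gives only a limit of the assay, > 30000 nM. Compound 2 `CC1(C)CCC(NCCCCN(C[C@H]2Cc3ccccc3CN2)[C@H]2CCCc3cccnc32)CC1` differs from compound 1 by 4,4-dimethylcyclohexyl in place of oxan-4-yl on an amine nitrogen. In this assay compound 2 also gives only a limit, > 30000 nM. Compound 3 `C(=C/CN(C[C@H]1Cc2ccccc2CN1)[C@H]1CCCc2cccnc21)\CNC1CCOCC1` differs from compound 1 by 3-((oxan-4-yl)amino)prop-1-en-1-yl in place of 3-((oxan-4-yl)amino)propyl on a saturated chain carbon bound to an amine nitrogen. In this assay compound 3 again gives only a limit, > 30000 nM. The step that the two limits leave unreadable from compound 1 to compound 2 cannot be sized because the limit of > 30000 nM in this assay, at which 3 of the 3 values shown sit, caps both ends, and the same holds for a step that the two limits leave unreadable from compound 1 to compound 3. Compound 4 `CC1(C)CCC(NC/C=C/CN(C[C@H]2Cc3ccccc3CN2)[C@H]2CCCc3cccnc32)CC1` differs from compound 3 by 4,4-dimethylcyclohexyl in place of oxan-4-yl on an amine nitrogen, the same change as from compound 1 to compound 2, at the same place. The step that the limit leaves unreadable from compound 3 to compound 4 is expected to be small, resting on the unreadable a step that the two limits leave unreadable from compound 1 to compound 2. Compound 4 is expected to give 40000 nM, likely again only a limit, within 10000 nM to 100000 nM.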

Compound 4, half-maximal effective concentration: > 30000 nM
Compound 4: no number, only a limit; the forecaster's own chance of this, stated with the estimate: 85%; the middle value is on the limit's open side.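

Within the data shown here, compound 3 and compound 4 both give only a limit, so no step between them can be read. In this assay, going by these compounds, none of the four compounds gives a number, and how far either change moves the value stays open.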